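A few compounds are considered here, and "the series" means these few. Any claim that something is new, unique, unknown or untested is made for them only; others in the source may bear on it.

Measured compounds:
compound 1 `O=C(Nc1cc(Sc2ncn[nH]2)c(O)c2ccccc12)c1cccc(Cl)c1`, 85600 nM
compound 2 `O=C(Nc1cc(Sc2ncn[nH]2)c(O)c2ccccc12)c1ccc(Cl)cc1`, 5520 nM

Going by the values given here, compound 2 holds the lowest of the two numbers in a functional assay on PC-3 cells (Homo sapiens) for antiproliferative activity, read by MTT assay, with a stated time of 48 h (a higher number here means a weaker inhibitor, a lower number a stronger inhibitor), and the one step recorded so far, a 16-fold lower number from compound 1 to compound 2 (1.19 log units; beyond the scatter), runs toward it. Compound 3 `Cc1cccc(C(=O)Nc2cc(Sc3ncn[nH]3)c(O)c3ccccc23)c1` differs from compound 2 by 3-methylphenyl in place of 4-chlorophenyl on a carbonyl carbon. Among the compounds with values here, only that single step bears on this change; it shows that moving the ring substituent from the 3-position to the 4-position lowered the number strongly, so returning a substituent to the 3-position is expected to raise it, though methyl differs from chlorine and the size is uncertain. Compound 3 is expected to give 30000 nM, between 8000 nM and 100000 nM, a step of a 5.4-fold higher number from compound 2 to compound 3 (0.74 log units; beyond the scatter).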

Compound 3, half-maximal inhibitory concentration: 59500 nM
The estimate for compound 3 lay 2.0-fold (0.30 log units) below the measured number; the range from low to high includes it.
By their numbers in this assay, from the lowest: compound 2; then compounds 3 and 1 (each within the scatter of the next).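

In this assay, replacing chloro with methyl on the aromatic carbon gives a 1.4-fold lower number from compound 1 to compound 3 (0.16 log units; within the scatter), so the two groups cannot be told apart in this assay when the ring pattern is otherwise kept. The change from 4-chlorophenyl to 3-methylphenyl gives an 11-fold higher number from compound 2 to compound 3 (1.03 log units; beyond the scatter), which leaves compound 2 clear of compound 3 on the carbonyl carbon. No measurement offers an explanation for either step. Going by these compounds, how an unsubstituted phenyl, a methoxyphenyl or an aminophenyl on that carbonyl carbon would compare remains open, and so does whether the lower number of compound 2 depends on its chloro group.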